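This account rests on a few compounds, and the source may have more. Where it says the series, first, only, none or still open, it means among the compounds named here.

In a functional assay on A2780 cells (Homo sapiens) for antiproliferative activity; a lower number here means a stronger inhibitor, a higher number a weaker inhibitor:
- compound 1 `Cc1ccc2c(c1C)CN(CCCN)CC2c1ccccc1`: 2420 nM
- compound 2 `Cc1ccc2c(c1C)CN(S(C)(=O)=O)CC2c1ccccc1`: "not determined" (no result reported)

Compound 2 has no place on the scale, so the series has a single number as its anchor. Compound 3 `Cc1ccc2c(c1C)CN(C(=O)N(C)C)CC2c1ccccc1` differs from compound 2 by dimethylcarbamoyl in place of methylsulfonyl on an amine nitrogen in a ring. No size can be given for this step, since one end lacks a number. Measured against compound 1 at 2420 nM, a modest shift towards weaker values is expected in this assay, with wide uncertainty. For compound 3 the expected value is 6000 nM, within an estimated range of 1500 nM to 25000 nM.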

Compound 3, half-maximal inhibitory concentration: 1200 nM
For compound 3 the middle estimate is 5.0-fold (0.70 log units) above the measured one; measured number outside the range, below it.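

In this assay, the amine nitrogen in a ring accepts dimethylcarbamoyl in place of 3-aminopropyl with no change beyond the scatter, a 2.0-fold lower number from compound 1 to compound 3 (0.30 log units; within the scatter), so the terminal amine of the chain is not required at this position in this pair. The step from compound 2 cannot be read, as compound 2 has no number. Nothing at hand bears on the reason for this result.

Open, on these data alone, is whether a longer amino chain, a carboxylic acid or a simple acetyl on this nitrogen would shift the value beyond the scatter. The role of the phenyl group also remains open, since it is the same in all compounds shown.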